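This account rests on a few compounds, and the source may have more. Where it says the series, first, only, none or still open, it means among the compounds named here.

Compound 1 `C#Cc1cn([C@@H]2O[C@H](CO)[C@@H](O)[C@H]2O)c2nc(C)nc(N)c12`, compound 2 `Cc1nc(N)c2c(I)cn([C@@H]3O[C@H](CO)[C@@H](O)[C@H]3O)c2n1` and compound 3 `C#Cc1cn([C@@H]2O[C@H](CO)[C@@H](O)[C@H]2O)c2ncnc(OC)c12` were tested in a functional assay on HL-60 cells (Homo sapiens) for antiproliferative activity, read by XTT assay, with a stated time of 72 h (on this read-out lower numbers stand for stronger inhibition and higher numbers for weaker inhibition), and compound 4 `COc1ncnc2c1c(I)cn2[C@@H]1O[C@H](CO)[C@@H](O)[C@H]1O` awaits measurement there. In this assay compound 1 gives only a limit, > 20000 nM, rather than a number. Compound 2 gives 2050 nM in this assay. Between them lies one change, (iodo in place of ethynyl on an aromatic carbon), and it brought an at least 9.7-fold lower number from compound 1 to compound 2 (0.98 log units; beyond the scatter); the size of that step can only be bounded because compound 1 sits at the limit of > 20000 nM in this assay, at which 1 of the 3 values shown sits. Compound 3 gives 190 nM in this assay, the lowest of the two numbers recorded. Compound 3 and compound 1 share no counted difference; the difference between the two cores is not broken down here. Compound 4 is made from compound 3 by the same change, (iodo in place of ethynyl on an aromatic carbon), and the two place descriptions agree word for word. Since compound 1 stands at a limit, the earlier step gives only a floor for what the change can do, so a smaller step is expected here: compound 4 is estimated at 80 nM, meaning an expected step of a 2.4-fold lower number from compound 3 to compound 4 (0.38 log units; beyond the scatter), somewhere between 20 nM and 400 nM.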

Compound 4, half-maximal inhibitory concentration: 2300 nM
Compound 4: the middle estimate sits 29-fold (1.46 log units) below what was measured, and the stated range ends below it.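

In this assay, iodo in place of ethynyl on an aromatic carbon brought a 12-fold higher number from compound 3 to compound 4 (1.08 log units; beyond the scatter) on the core of compound 3, so the step seen on the core of compound 1 did not carry over, even in direction: the same change on two cores in this assay, an at least 9.7-fold lower number (0.98 log units; beyond the scatter) from compound 1 to compound 2 and a 12-fold higher number (1.08 log units; beyond the scatter) from compound 3 to compound 4, at least 110-fold (2.07 log units) apart, beyond the scatter of two such steps. The earlier step can only be bounded, since compound 1 stands at a limit and not at a number: the limit of > 20000 nM in this assay, at which 1 of the 4 values shown sits. The result shows that in this series the change cannot be read across these two cores, but it does not show which of the differences between them turns the step around, and it rests on just one pair per core.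

The compounds shown leave open how a bromo group, a nitrile or a longer alkyne chain on that same aromatic carbon would fare on either core. They also leave open how the change would read on a core that carries only one of the differences between the two cores.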